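This account rests on a few compounds, and the source may have more. Where it says the series, first, only, none or still open, it means among the compounds named here.

Measured so far in a functional assay on K562 cells (Homo sapiens) for cytotoxicity, read by trypan blue exclusion, with a stated time of 96 h; a lower number here means a stronger inhibitor, a higher number a weaker inhibitor:
compound 1, `COc1ccc(NS(=O)(=O)/C=C/c2c(F)c(F)c(F)c(F)c2F)cc1F`, 10000 nM
compound 2, `COc1ccc(NS(=O)(=O)/C=C/c2c(F)c(F)c(F)c(F)c2F)cc1`, 5000 nM
compound 3, `COC(=O)C(Nc1cc(NS(=O)(=O)/C=C/c2c(OC)cc(OC)cc2OC)ccc1OC)c1ccccc1`, 2500 nM

The core of compound 3 differs from the core of compound 2 in more than one place; the difference between the two cores is not broken down here. Compound 4, `COC(=O)C(Nc1cc(NS(=O)(=O)/C=C/c2c(OC)cc(OC)cc2OC)ccc1OC)c1ccc(F)cc1`, differs from compound 3 only by fluoro in place of hydrogen on an aromatic carbon. The same kind of change has already been measured: compound 1 differs from compound 2 by fluoro in place of hydrogen on an aromatic carbon, and in this assay that gave a 2.0-fold higher number from compound 2 to compound 1 (0.30 log units; within the scatter). The two places are not the same, however: in compound 1 the fluoro sits ortho to a methoxy group and meta to a large group, in compound 4 para to a large group, so it is the same kind of change, not the same change. Because the earlier step was a 2.0-fold higher number from compound 2 to compound 1 (0.30 log units; within the scatter), the step from compound 3 to compound 4 is expected to be of similar size, a 1.4-fold higher number from compound 3 to compound 4 (0.15 log units; within the scatter). Compound 4 is therefore estimated at 3500 nM, expected between 1200 nM and 9000 nM.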

Compound 4, half-maximal inhibitory concentration: 2500 nM
For compound 4 the middle estimate is 1.4-fold (0.15 log units) above the measured one; the measured number falls inside the stated range.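

In this assay, fluoro in place of hydrogen on an aromatic carbon gave no change at the digits printed from compound 3 to compound 4 (within the scatter). Set beside the earlier case on the other core, the step shows no difference beyond the scatter: the same change on two cores in this assay, a 2.0-fold higher number (0.30 log units; within the scatter) from compound 2 to compound 1 and no change at the digits printed (within the scatter) from compound 3 to compound 4, 2.0-fold (0.30 log units) apart, within the scatter of two such steps Within these two pairs, then, the change left the number within the scatter on both cores, but this does not show that it would do so on every core of the series or at every place on a ring, and the fluoro occupies a different place in each pair.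

The compounds shown leave open how the number would move with chloro or an amine at the place para to a large group in compound 4. They also leave open what a carboxylic acid would do in place of the methyl ester.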